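Changing the ether tail on a shared benzamide core

The source may report more compounds than this note shows. Statements on the series, on what has been measured and on what is new or still open speak of the compounds shown alone.

Compound 1 `COc1ccc(C(=O)N(Cc2ccncc2)Cc2cccc(OCCc3ccc(C)cc3)c2)cc1` gives 9100 nM in a functional assay on KMS-11 cells (Homo sapiens) for antiproliferative activity, read by CellTiter-Glo, with a stated time of 72 h; on this read-out lower numbers stand for stronger inhibition and higher numbers for weaker inhibition.
Compound 2 `COc1ccc(C(=O)N(Cc2ccncc2)Cc2cccc(OCCc3ccc(Br)cc3)c2)cc1` gives 8400 nM.
Compound 3 `COc1ccc(C(=O)N(Cc2ccncc2)Cc2cccc(OCC(=O)c3cccc(Br)c3)c2)cc1` gives 18700 nM.

On these three numbers compound 1 stands second highest. Its nearest neighbour is compound 2, with a 1.1-fold lower number from compound 1 to compound 2 (0.03 log units; within the scatter), a step within the scatter. Its furthest is compound 3, with a 2.1-fold higher number from compound 1 to compound 3 (0.31 log units; beyond the scatter), a modest step beyond the scatter, and compound 2 shows the same picture in a 2.2-fold higher number from compound 2 to compound 3 (0.35 log units; beyond the scatter).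

Compound 4 `COc1ccc(C(=O)N(Cc2ccncc2)Cc2cccc(OCc3cccc([N+](=O)[O-])c3)c2)cc1` is reached from compound 1 by 3-nitrophenyl in place of 4-methylbenzyl on a saturated chain carbon bound to an oxygen on an aromatic ring.

Among the compounds with values here, no measured step places a nitro group on the ring of the tail, so none bears directly on this change. Within the data shown here, the only steps at the saturated chain carbon bound to an oxygen on an aromatic ring are a 2.1-fold higher number from compound 1 to compound 3 (0.31 log units; beyond the scatter) and a 2.2-fold higher number from compound 2 to compound 3 (0.35 log units; beyond the scatter), both modest rises. A small step of that order, toward a higher number or none beyond the scatter, is therefore expected for compound 4, as a 1.3-fold higher number from compound 1 to compound 4 (0.12 log units; within the scatter).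

Compound 4 is estimated at 12000 nM, in a range from 5000 nM to 30000 nM.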

Compound 4, half-maximal inhibitory concentration: 19600 nM
Estimate against measurement, compound 4: 1.6-fold (0.21 log units) below; measured number inside the range.
By their numbers in this assay, from the lowest: compounds 2 and 1 (each within the scatter of the next); then compounds 3 and 4 (each within the scatter of the next).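

Measured in this assay, the 3-nitrophenyl tail gives a 2.2-fold higher number from compound 1 to compound 4 (0.33 log units; beyond the scatter) and a 2.3-fold higher number from compound 2 to compound 4 (0.37 log units; beyond the scatter), both modest rises of the same order as those seen with the (3-bromophenyl)carbonyl tail. The new comparison between the two replaced tails is a 1.0-fold higher number from compound 3 to compound 4 (0.02 log units; within the scatter), so it does not separate them. At this position, therefore, a second and differently built tail lands at the level of compound 3, and the rise from compounds 1 and 2 is not confined to the carbonyl-bearing tail. No measurement shown here accounts for this shared level.

From the compounds shown here alone, whether an amine or a carboxylic acid on the ring of the tail would shift the number remains open. So does whether a longer chain carrying the 3-nitrophenyl ring would return to the level of compounds 1 and 2.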